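This account rests on a few compounds, and the source may have more. Where it says the series, first, only, none or still open, it means among the compounds named here.

Three compounds share one core, and in this study it is tested in a functional assay on SW1573 cells (Homo sapiens) for antiproliferative activity; a higher number here means a weaker inhibitor of growth, a lower number a stronger inhibitor of growth. There compound 1 `C[C@H]1CC(Cl)=C[C@@H](C2CCCCC2)O1` gives 43000 nM, compound 2 `CC[C@H]1CC(Cl)=C([Si](C)(C)C)[C@@H](C2CCCCC2)O1` gives 49000 nM, and compound 3 `C[C@@H]1O[C@H](C2CCCCC2)C([Si](C)(C)C)=C(Cl)[C@H]1C` gives 41000 nM. Compound 3 holds the lowest of the three numbers, yet its gaps to compound 1 and to compound 2 both lie within the scatter, so the three cannot be ranked. Compound 4 `C=CCC[C@H]1O[C@@H](C)[C@H](C)C(Cl)=C1[Si](C)(C)C` differs from compound 3 in one place: but-3-en-1-yl in place of cyclohexyl on a saturated ring carbon. Within the data shown here, no measured pair shows what this swap does, and the three measured values sit close together, so no step beyond the scatter is expected in either direction. Compound 4 is therefore estimated at 45000 nM, within 20000 nM to 100000 nM. That estimate means a step of a 1.1-fold higher number from compound 3 to compound 4 (0.04 log units; within the scatter).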

Compound 4, concentration for total growth inhibition: 55000 nM
Compound 4: the middle estimate sits 1.2-fold (0.09 log units) below what was measured; the range from low to high includes it.
By their numbers in this assay, from the lowest: compounds 3, 1, 2 and 4 (each within the scatter of the next).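

In this assay, but-3-en-1-yl in place of cyclohexyl on this saturated ring carbon, next to the ring oxygen, gives a step that lies within the scatter (a 1.3-fold higher number from compound 3 to compound 4 (0.13 log units; within the scatter)). Among these compounds, this is the first measured pair at this position, and it shows that here an open chain with a double bond and a carbon-only ring cannot be told apart. No measurement at hand speaks to the reason.

On these data alone, whether an amine, a carboxylic acid or a longer chain at this position would give a step beyond the scatter stays open. So does whether a phenyl ring would.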